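A few compounds are considered here, and "the series" means these few. Any claim that something is new, unique, unknown or untested is made for them only; others in the source may bear on it.

Of the compounds shown here, three built on a shared core have been tested in an ADME assay on HEK-293T cells (Homo sapiens) for cytotoxicity, read by CCK-8 assay, with a stated time of 48 h; a lower number here means a stronger inhibitor, a higher number a weaker inhibitor. Compound 1 `COc1cccc(NC(=S)NCCNS(=O)(=O)c2ccc(-c3ccccc3Oc3ccc([N+](=O)[O-])cc3)s2)c1` reaches only a limit there, > 20000 nM, which is not a number. Going by the values given here, compound 3 `Cc1ccc(-c2ccsc2S(=O)(=O)NCCNC(=O)Nc2cccc([N+](=O)[O-])c2)c(Oc2ccc(O)c(O)c2)c1` gives 6800 nM in this assay and is the one member of the set with a measured value. Compound 2 `O=C(NCCNS(=O)(=O)c1ccc(-c2ccccc2Oc2ccc([N+](=O)[O-])c([N+](=O)[O-])c2)s1)Nc1cc(C(F)(F)F)cc(C(F)(F)F)c1` likewise returns only a limit in this assay, > 50000 nM. Compound 2 thus stands at the edge of what this assay reports, on the line (the limit of > 50000 nM in this assay, at which 1 of the 3 values shown sits), with no number of its own; of the three values shown, one further value is also a limit, on the line (the limit of > 20000 nM in this assay, at which 1 of the 3 values shown sits).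

The next compound, compound 4 `O=C(NCCNS(=O)(=O)c1ccc(-c2ccccc2OCc2cccc(O)c2)s1)Nc1cc(C(F)(F)F)cc(C(F)(F)F)c1`, is not yet measured in this assay. Its difference from compound 2 is 3-hydroxybenzyl in place of 3,4-dinitrophenyl on an oxygen on an aromatic ring.

Among the compounds with values here, no step between two measured compounds is available to calibrate this change, so the expectation rests on the values themselves. Compound 2 shows no measurable cytotoxicity, and compound 4 is expected to stay weak as well, with the estimated step of an at least 1.2-fold lower number from compound 2 to compound 4 (0.09 log units; that floor lies within the scatter) amounting to nothing beyond the usual scatter, though a number inside the range of this assay cannot be excluded. Compound 4 is therefore estimated at 40000 nM, within a range from 10000 nM to 120000 nM.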

Compound 4, half-maximal inhibitory concentration: > 20000 nM
Compound 4 was reported as a limit; the forecaster's own chance of this, stated with the estimate: 60%; the middle value lies beyond the limit too.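

In this assay compound 4 gives > 20000 nM, which is a limit and not a number. Going by these compounds alone, compound 2 also gives only a limit, > 50000 nM, so no step between compound 2 and compound 4 can be read. The compounds shown leave open whether 3-hydroxybenzyl in place of 3,4-dinitrophenyl changes this read-out at all.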